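Replacing the Seven-Membered Ring with Phenylpiperazine

The compounds below may be only part of what the source reports. "The series", "measured", "known", "first", "only" and "open" are said of these compounds alone.

Compound 1 `CC1CCN(c2nc(C(F)(F)Cl)ccc2CNC(=O)C(C)c2ccc(NS(C)(=O)=O)c(F)c2)CC1` gives 0.3 nM in an assay on CHO cells for antagonist activity at transient receptor potential cation channel subfamily V member 1 (Homo sapiens), read by FLIPR; a higher number here means a weaker inhibitor, a lower number a stronger inhibitor. Compound 2 `CC(C(=O)NCc1ccc(C(F)(F)Cl)nc1N1CCCCC1)c1ccc(NS(C)(=O)=O)c(F)c1` gives 1.3 nM. Compound 3 `CC(C(=O)NCc1ccc(C(F)(F)Cl)nc1N1CCCCCC1)c1ccc(NS(C)(=O)=O)c(F)c1` gives 0.5 nM.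

Among these three, compound 3 stands second highest: it sits nearest compound 1, with a 1.7-fold higher number from compound 1 to compound 3 (0.22 log units; within the scatter), and furthest from compound 2, with a 2.6-fold lower number from compound 2 to compound 3 (0.41 log units; beyond the scatter). Compound 4 `CC(C(=O)NCc1ccc(C(F)(F)Cl)nc1N1CCN(c2ccccc2)CC1)c1ccc(NS(C)(=O)=O)c(F)c1` differs from compound 3 in one place: 4-phenylpiperazin-1-yl in place of azepan-1-yl on an aromatic carbon. For the measured compounds named here, the steps that bear on this change are a 2.6-fold lower number from compound 2 to compound 3 (0.41 log units; beyond the scatter) and a 4.3-fold higher number from compound 1 to compound 2 (0.64 log units; beyond the scatter), both modest alterations of the same saturated ring. Neither involves a group as large as the one entering, so a modest weakening beyond the scatter is expected, a 3.0-fold higher number from compound 3 to compound 4 (0.48 log units; beyond the scatter). Compound 4 is therefore estimated at 1.5 nM, with a range from 0.3 nM to 8 nM.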

Compound 4, inhibition constant: 0.8 nM
For compound 4 the middle estimate is 1.9-fold (0.27 log units) above the measured one; measured number inside the range.
By their numbers in this assay, from the lowest: compounds 1, 3, 4 and 2 (each within the scatter of the next, the first and the last beyond it).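

Both a 1.6-fold higher number from compound 3 to compound 4 (0.20 log units; within the scatter) and a 1.6-fold lower number from compound 2 to compound 4 (0.21 log units; within the scatter) show that in this assay the aromatic carbon next to the ring nitrogen accepts 4-phenylpiperazin-1-yl, a larger group carrying a second ring, with no change beyond the scatter. For the compounds shown here, the only step beyond it is a 2.7-fold higher number from compound 1 to compound 4 (0.43 log units; beyond the scatter) and it remains modest. No evidence at hand accounts for this result.

On these data alone, it remains open whether a fluoro or methoxy group on the phenyl ring would hold this level. The same applies to a benzyl group in place of the phenyl, or to a piperazine carrying only a methyl group.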